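Para-substituent swap in a series at the assay limit

The compounds below may be only part of what the source reports. "The series", "measured", "known", "first", "only" and "open" are said of these compounds alone.

In a functional assay on PANC-1 cells (Homo sapiens) for cytotoxicity, read by WST assay, with a stated time of 24 h (a lower number here means a stronger inhibitor, a higher number a weaker inhibitor), compound 1 (`O=C(/C=C/CCCCCCc1ccccc1)N1CCCCCC1`) gives > 100000 nM as a limit of the assay, not a number. Compound 2 (`Cc1ccc(CCCCCCCCC(=O)N2CCCCC2)cc1`) gives > 100000 nM as a limit as well, so it has no numerical position in the series. Within the data shown here, both measured compounds stand at one value (the limit of > 100000 nM in this assay, at which 2 of the 2 values shown sit) and no measured step is available to size a change.

Compound 3 (`O=C(CCCCCCCCc1ccc(F)cc1)N1CCCCC1`) has fluoro in place of methyl on an aromatic carbon, para to a large group (fluoro in place of methyl on an aromatic carbon).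

In this assay no step beyond the scatter is expected, and no direction can be assigned. That expectation rests on compound 2, with its limit of > 100000 nM in the same assay. The expected change is a number no higher from compound 2 to compound 3 (the limit leaves the size open). For compound 3 the estimated value is 100000 nM with an expected range of 50000 nM to 200000 nM in this read-out.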

Compound 3, half-maximal inhibitory concentration: 99800 nM
Compound 3: the middle estimate sits 1.0-fold (0.00 log units) above what was measured; the measured number falls inside the stated range.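

Among these compounds, compound 3 gives the first actual number in this assay, 99800 nM, so the aromatic carbon para to a large group now carries one readable value. Fluoro in place of methyl at this place gives a number no higher from compound 2 to compound 3 (the limit leaves the size open), and the size of this step cannot be read, so the change shows no measurable effect of either group. Most of the series still has no numerical position, and compound 2 remains a limit rather than a number: the limit of > 100000 nM in this assay, at which 2 of the 3 values shown sit.

From the compounds shown here alone, it remains open whether any group on this aromatic carbon can move the value clearly away from the limit, for example an amine or a carboxylic acid in place of fluoro. Also open, going by these compounds, is whether a shorter or longer chain in the shared core would leave the fluoro and methyl compounds as close together.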